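The source may hold more compounds than are shown below. What is called first, only, known or untested is meant among the compounds shown, and "the series" means these compounds.

Three measured compounds share one core and differ only in the group attached through a sulfur or an oxygen on that core: compound 1 `CCCCCSc1nc(C(C)(C)C)ccc1CNC(=O)C(C)c1ccc(NS(C)(=O)=O)c(F)c1`, compound 2 `COc1ccc(CSc2nc(C(C)(C)C)ccc2CNC(=O)C(C)c2ccc(NS(C)(=O)=O)c(F)c2)cc1` and compound 3 `CCCOc1cc(C(C)(C)C)ccc1CNC(=O)C(C)c1ccc(NS(C)(=O)=O)c(F)c1`. In an assay on cells for antagonist activity at transient receptor potential cation channel subfamily V member 1 (Homo sapiens), read by FLIPR and calcium flux, with a stated time of 6 min (on this read-out lower numbers stand for stronger inhibition and higher numbers for weaker inhibition), compound 1 gives 3.1 nM, compound 2 gives 3.5 nM and compound 3 gives 4.4 nM. Compound 3 therefore has the highest of the three numbers, but its gaps to compound 2 and to compound 1 are both within the scatter, so no order among the three can be claimed.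

Within the data shown here, only one measured pair differs in a single place: a 1.1-fold higher number from compound 1 to compound 2 (0.05 log units; within the scatter), a swap of an alkyl chain for an aromatic ring on a saturated chain carbon bound to a sulfur, and that swap left the number unchanged within the scatter.

Compound 4 `CC(C(=O)NCc1ccc(C(C)(C)C)cc1OCc1ccc(F)cc1)c1ccc(NS(C)(=O)=O)c(F)c1` is not yet measured. It differs from compound 3 in one place: 4-fluorophenyl in place of ethyl on a saturated chain carbon bound to an oxygen on an aromatic ring. This mirrors the measured swap closely, an alkyl chain again giving way to an aromatic ring on a chain carbon. Because a 1.1-fold higher number from compound 1 to compound 2 (0.05 log units; within the scatter) stayed within the scatter, the expected step of a 1.0-fold higher number from compound 3 to compound 4 (0.01 log units; within the scatter) is none beyond the scatter. Compound 4 is thus estimated to give 4.5 nM, with a range from 2 nM to 10 nM.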

Compound 4, inhibition constant: 3.8 nM
Compound 4: middle estimate off by 1.2-fold (0.07 log units), on the high side; measured number inside the range.
By their numbers in this assay, from the lowest: compounds 1, 2, 4 and 3 (each within the scatter of the next).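

In this assay, putting 4-fluorophenyl (7 heavy atoms, one six-membered aromatic ring) in place of ethyl (2 heavy atoms, no ring) gives a 1.2-fold lower number from compound 3 to compound 4 (0.06 log units; within the scatter) and so stays within the scatter. The earlier swap of an alkyl chain for an aromatic ring, a 1.1-fold higher number from compound 1 to compound 2 (0.05 log units; within the scatter) on a chain carbon bound to a sulfur, also stayed within the scatter, and the new step shows the same on a saturated chain carbon bound to an oxygen on an aromatic ring. No measurement is at hand that explains this outcome.

Going by these compounds, it remains open whether the fluorine matters, which a plain phenyl at this place would test. Also open, on these data alone, is whether a group such as an amine or a carboxylic acid on this chain carbon would leave the number just as unchanged.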